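From Substituted Phenyl to a Chlorophenylpropyl Chain

The source may report more compounds than this note shows. Statements on the series, on what has been measured and on what is new or still open speak of the compounds shown alone.

Compound 1 `Nc1scc(CN2CCN(c3ccc(F)cc3Cl)CC2)c1C(=O)c1ccc(Cl)cc1` was tested in a functional assay on CHO cells with adenosine receptor A1 (Homo sapiens) as the target, read by cAMP accumulation and immunoassay, with a stated time of 6 min, tested at 0.1 uM (on this read-out lower numbers stand for a stronger effect and higher numbers for a weaker effect at the one concentration tested), where compound 1 gives -6.2%. Two companions share its core and differ only in the group carried on an amine nitrogen in a ring. In this assay compound 2 `Nc1scc(CN2CCN(c3ccc(Cl)c(C(F)(F)F)c3)CC2)c1C(=O)c1ccc(Cl)cc1` gives -12%, and compound 3 `Nc1scc(CN2CCN(c3cccc(F)c3F)CC2)c1C(=O)c1ccc(Cl)cc1` gives -5.2%. Compound 1 therefore holds the second highest of the three numbers; its nearest neighbour is compound 3 and its furthest is compound 2, and both gaps stay within the scatter: a number 1 percentage points higher from compound 1 to compound 3 (within the scatter) and a number 5.8 percentage points lower from compound 1 to compound 2 (within the scatter). The remaining pair behaves the same way, a number 6.8 percentage points higher from compound 2 to compound 3 (within the scatter), so none of the three exchanges of one substituted phenyl for another moves the read-out beyond the noise.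

Compound 4 `Nc1scc(CN2CCN(CCCc3ccc(Cl)cc3)CC2)c1C(=O)c1ccc(Cl)cc1` differs from compound 1 by 3-(4-chlorophenyl)propyl in place of 2-chloro-4-fluorophenyl on an amine nitrogen in a ring. Here the group that enters is a 3-(4-chlorophenyl)propyl chain rather than a substituted phenyl ring, a kind of change that none of the measured steps tests; they bear on it only loosely, by showing that this position has tolerated every swap so far without a shift beyond the scatter. The step expected in this assay is accordingly a number 0.8 percentage points lower from compound 1 to compound 4 (within the scatter), with no direction beyond the scatter. Compound 4 is estimated at -7%, within a range from -25% to 10%, widened because the measured steps such as a number 5.8 percentage points lower from compound 1 to compound 2 (within the scatter) involve a different type of group.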

Compound 4, a percentage reported as activity, at one concentration (the size of the read-out at that concentration, not a potency): -3%
Beside the measured number, compound 4's estimate is 4 percentage points below it; measured number inside the range.
By their numbers in this assay, from the lowest: compounds 2, 1, 3 and 4 (each within the scatter of the next).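

The first chain at this position, 3-(4-chlorophenyl)propyl, leaves the read-out in this assay within the scatter of all three substituted phenyl compounds (a number 3.2 percentage points higher from compound 1 to compound 4 (within the scatter); a number 2.2 percentage points higher from compound 3 to compound 4 (within the scatter); a number 9 percentage points higher from compound 2 to compound 4 (within the scatter)). The tolerance on the amine nitrogen in a ring is therefore no longer confined to exchanges of one substituted phenyl for another: among these four compounds it also covers a propyl chain carrying the aromatic ring, a group of 10 heavy atoms in place of the 8 of 2-chloro-4-fluorophenyl. No accompanying measurement explains why the read-out stays so steady across this change.

Still open, from the compounds shown here alone, is how far this tolerance extends, for instance to a shorter or longer chain, to a chain ending in an amine or a carboxylic acid, or to a propyl chain ending in an unsubstituted phenyl ring. With a single concentration and every compound within the scatter of the next, these results also cannot show whether potency differs among the four compounds at other concentrations.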